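The source may hold more compounds than are shown below. What is called first, only, known or untested is meant among the compounds shown, and "the series" means these compounds.

Compound 2 `CC(C)(C)c1conc1N1C(=O)CSC1c1cccc(C(=O)NCCCCc2ccccc2)c1` was tested in a functional assay on HOS-TE85 cells (Homo sapiens) for inhibition, read by CCK-8 assay, with a stated time of 72 h (a lower number here means a stronger inhibitor, a higher number a weaker inhibitor), together with two related compounds sharing its core. Compound 1 `O=C(NCCCCc1ccccc1)c1cc(F)cc(C2SCC(=O)N2c2ccccn2)c1` gives 14.2 nM, and compound 3 `COc1ccccc1N1C(=O)CSC1c1cccc(C(=O)NCCCCn2cccn2)c1` gives 91.7 nM. For compound 2 only a limit is known: it reaches > 1000 nM, which is the edge of what this assay reports rather than a number, as shown by the limit of > 1000 nM in this assay, at which 1 of the 3 values shown sits. Compound 4 `O=C(NCCCCc1ccccc1)c1cccc(C2SCC(=O)N2c2cccc(F)c2)c1` has not yet been measured. It differs from compound 2 in one place: a group of 7 heavy atoms (6 carbon, 1 fluorine; one six-membered aromatic ring of carbon only) in place of a group of 9 heavy atoms (7 carbon, 1 nitrogen, 1 oxygen; one five-membered aromatic ring with 2 hetero atoms), on an amide-type nitrogen in a ring. Among the compounds with values here, no pair of measured compounds differing in exactly this way exists, so the step can only be expected, not read off. The ring that enters resembles the six-membered rings carried at the same place by compound 1 and compound 3, both of which give numbers well inside the measurable range. Compound 4 is therefore expected to be a clearly stronger inhibitor than compound 2, with an estimated value of 50 nM and a range from 15 nM to 200 nM, an expected step of an at least 20-fold lower number from compound 2 to compound 4 (1.30 log units; beyond the scatter).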

Compound 4, half-maximal inhibitory concentration: 32.4 nM
Beside the measured number, compound 4's estimate is 1.5-fold (0.19 log units) above it; measured number inside the range.
By their numbers in this assay, from the lowest: compound 1; then compound 4; then compound 3. At a limit, above all of these: compound 2.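

Placing 3-fluorophenyl on the amide-type nitrogen in a ring, in place of the five-membered aromatic group, gives an at least 30-fold lower number from compound 2 to compound 4 (1.48 log units; beyond the scatter). Within the data shown here, this is the first comparison of compounds differing in one place, and it shows that the group here can decide whether the compound has a measurable effect in this test. Compound 2 stands at a limit rather than a number, so the step gives only a minimum size: the limit of > 1000 nM in this assay, at which 1 of the 4 values shown sits.

On these data alone, how much of the step depends on the fluorine remains open, and a plain phenyl at this place would help separate that. Whether the ring accepts an amine or a carboxylic acid is also unknown.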